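Notes on the aryl-amine swap toward compound 4

The source may report more compounds than this note shows. Statements on the series, on what has been measured and on what is new or still open speak of the compounds shown alone.

Three members of the shared core have been measured: compound 1 `N#Cc1c(Nc2ccccc2Cl)nc(SCc2cn(Cc3ccccc3Cl)nn2)nc1-c1ccccc1`, compound 2 `Cc1ccc(Cn2cc(CSc3nc(Nc4ccccc4F)c(C#N)c(-c4ccccc4)n3)nn2)cc1` and compound 3 `Cc1ccc(Cn2cc(CSc3nc(Nc4ccc(C)cc4)c(C#N)c(-c4ccccc4)n3)nn2)cc1`. In a functional assay on B16-F10 cells (Mus musculus) for inhibition, read by MTT assay, with a stated time of 72 h (on this read-out lower numbers stand for stronger inhibition and higher numbers for weaker inhibition), compound 1 gives 8350 nM, compound 2 gives 16000 nM and compound 3 gives 8160 nM. Compound 3 holds the lowest of the three numbers, yet its gaps to both others lie within the scatter. Going by the values given here, the single counted step, a 2.0-fold lower number from compound 2 to compound 3 (0.29 log units; within the scatter), is likewise within the scatter. Compound 4 `Cc1ccc(Cn2cc(CSc3nc(Nc4ccccc4Cl)c(C#N)c(-c4ccccc4)n3)nn2)cc1` differs from compound 3 by 2-chlorophenyl in place of 4-methylphenyl on a nitrogen on an aromatic ring. Among the compounds with values here, no measured step carries exactly this change; compound 1 also bears a 2-chlorophenyl on the same nitrogen and its number sits close to that of compound 3, though compound 1 differs in a second place as well. The expected step of a 1.1-fold higher number from compound 3 to compound 4 (0.04 log units; within the scatter) is therefore none beyond the scatter. Compound 4 is estimated at 9000 nM, with a range of 4000 nM to 20000 nM.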

Compound 4, half-maximal inhibitory concentration: 7080 nM
Beside the measured number, compound 4's estimate is 1.3-fold (0.10 log units) above it; low and high end bracket the measured number.
By their numbers in this assay, from the lowest: compounds 4, 3, 1 and 2 (each within the scatter of the next, the first and the last beyond it).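

In this assay the swap on the nitrogen gives a 1.2-fold lower number from compound 3 to compound 4 (0.06 log units; within the scatter) and so does not separate 2-chlorophenyl from 4-methylphenyl at this position. Chloro in place of fluoro on an aromatic carbon gives a 2.3-fold lower number from compound 2 to compound 4 (0.35 log units; beyond the scatter) and is the only step so far to pass the scatter, and only modestly. On the saturated chain carbon bound to an aromatic nitrogen, the exchange gives a 1.2-fold lower number from compound 1 to compound 4 (0.07 log units; within the scatter) and shows no separation either. From the compounds shown here alone, whether an amine or a carboxylic acid on the phenyl ring at this nitrogen would shift the number stays open. Nothing at hand explains these numbers.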